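A Hydroxyethoxyethyl Amide Examined for Cytotoxicity

A few compounds are considered here, and "the series" means these few. Any claim that something is new, unique, unknown or untested is made for them only; others in the source may bear on it.

Three measured compounds share one core and differ only in the group on the carbonyl carbon. Compound 1 `CCOC(=O)/C=C/c1cnc(Nc2ccc(C#N)cc2)nc1Oc1c(C)cc(C#N)cc1C` bears ethoxy there, compound 2 `Cc1cc(C#N)cc(C)c1Oc1nc(Nc2ccc(C#N)cc2)ncc1/C=C/C(=O)NC1CC1` cyclopropylamino, and compound 3 `COCCNC(=O)/C=C/c1cnc(Nc2ccc(C#N)cc2)nc1Oc1c(C)cc(C#N)cc1C` (2-methoxyethyl)amino. In an ADME assay on TZM cells (Homo sapiens) for cytotoxicity, with a stated time of 1 days (on this read-out lower numbers stand for higher toxicity in this test and higher numbers for lower toxicity in this test), compound 1 gives > 227 nM, a limit of the assay rather than a number. Compound 2 gives > 221 nM, also a limit. Compound 3 gives > 213 nM, again a limit. Compound 2 thus stands only at a limit, as do both other values. The step most relevant to compound 4 `Cc1cc(C#N)cc(C)c1Oc1nc(Nc2ccc(C#N)cc2)ncc1/C=C/C(=O)NCCOCCO`, which differs from compound 2 by 2-(2-hydroxyethoxy)ethyl in place of cyclopropyl on an amide-type nitrogen, is a step that the two limits leave unreadable from compound 2 to compound 3; the steps a step that the two limits leave unreadable from compound 1 to compound 2 and a step that the two limits leave unreadable from compound 1 to compound 3 are likewise unreadable. No step beyond the scatter is expected in this assay. Compound 4 is expected to give 260 nM, within 150 nM to 700 nM. That estimate is expected to mean a step that the limit leaves unreadable from compound 2 to compound 4.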

Compound 4, half-maximal cytotoxic concentration: > 200 nM
Compound 4 was reported as a limit; the forecaster's own chance of this, stated with the estimate: 85%; the middle value lies beyond the limit too.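

Compound 4, like compound 1, compound 2 and compound 3, is reported in this assay only as a limit, so no step among these compounds can be read. The compounds shown leave open where the half-maximal cytotoxic concentration of any of them actually lies.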